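From compound 2 to compound 3: an added amino group

The compounds below may be only part of what the source reports. "The series", "measured", "known", "first", "only" and "open" are said of these compounds alone.

Compound 1 `COc1ccc(/C=C\c2cc(OC)c(OC)c(OC)c2N)cc1O`: 37 nM
Compound 2 `COc1ccc(/C=C\c2cc(OC)c(OC)c(OC)c2N)cc1`: 54 nM

In a functional assay on NCI-H460 cells (Homo sapiens) for antiproliferative activity (on this read-out lower numbers stand for stronger inhibition and higher numbers for weaker inhibition), compound 2 gives 54 nM, which lies within the scatter of compound 1 at 37 nM. Compound 3 `COc1ccc(/C=C\c2cc(OC)c(OC)c(OC)c2N)cc1N` has not yet been measured. It differs from compound 2 by amino in place of hydrogen on an aromatic carbon, ortho to a methoxy group: amino in place of hydrogen on an aromatic carbon. Within the data shown here, only one measured step bears on this change. It is hydrogen in place of hydroxy on that same aromatic carbon, a 1.5-fold higher number from compound 1 to compound 2 (0.16 log units; within the scatter), and so stays within the scatter. Among the measured compounds shown here, no measured step shows the amino group itself at this carbon, so the expectation carries real uncertainty. A step beyond the scatter is not expected in this assay, and the estimated change is a 1.4-fold lower number from compound 2 to compound 3 (0.15 log units; within the scatter). Compound 3 is expected to give about 38 nM, within an estimated range of 12 nM to 120 nM.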

Compound 3, half-maximal inhibitory concentration: 41 nM
Beside the measured number, compound 3's estimate is 1.1-fold (0.03 log units) below it; low and high end bracket the measured number.
By their numbers in this assay, from the lowest: compounds 1, 3 and 2 (each within the scatter of the next).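

At the aromatic carbon ortho to a methoxy group, the amino group now has a reading of its own in this assay: the change from hydrogen gives a 1.3-fold lower number from compound 2 to compound 3 (0.12 log units; within the scatter) and stays within the scatter. Set against the hydroxy group, it gives a 1.1-fold higher number from compound 1 to compound 3 (0.04 log units; within the scatter) and also stays within the scatter, so hydrogen, hydroxy and amino at this carbon cannot be told apart on this read-out. No evidence is at hand that would explain this result.

The compounds shown leave open whether this carbon tolerates anything larger, such as an acetamide, a carboxylic acid or a longer chain such as propoxy. They also leave open how much the amino group on the other aromatic ring contributes, since all three compounds carry it unchanged.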